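Trimethoxyphenyl in place of dichlorophenyl: a cytotoxicity question

The source may report more compounds than this note shows. Statements on the series, on what has been measured and on what is new or still open speak of the compounds shown alone.

In a functional assay on A549 cells (Homo sapiens) for cytotoxicity, read by MTT assay, with a stated time of 72 h (on this read-out higher numbers stand for weaker inhibition and lower numbers for stronger inhibition), compound 1 (`COc1cc2ncnc(Nc3ccc(F)c(Cl)c3)c2cc1NC(=O)/C=C/c1ccc(F)cc1Cl`) is recorded as "not active" (no number reported), without a number. For the measured compounds named here, compound 2 (`O=C(/C=C/c1cccc(Cl)c1Cl)Nc1cc2c(Nc3ccc(F)c(Cl)c3)ncnc2cc1O[C@H]1CCOC1`) gives 23200 nM, the only number available, so it cannot yet be ranked against another value. Compound 3 (`COc1cc(/C=C/C(=O)Nc2cc3c(Nc4ccc(F)c(Cl)c4)ncnc3cc2O[C@H]2CCOC2)cc(OC)c1OC`) carries 3,4,5-trimethoxyphenyl in place of 2,3-dichlorophenyl on a double-bonded chain carbon bound to a double-bonded chain carbon. Going by the values given here, no measured step shows the effect of such a change. No shift beyond the scatter is therefore expected in this assay, with an estimated 1.2-fold lower number from compound 2 to compound 3 (0.06 log units; within the scatter). For compound 3 the expected value is 20000 nM, within a range of 7000 nM to 60000 nM.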

Compound 3, half-maximal inhibitory concentration: 4150 nM
Compound 3: middle estimate off by 4.8-fold (0.68 log units), on the high side; measured number outside the range, below it.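

On the double-bonded chain carbon bound to a double-bonded chain carbon, the choice of aryl group changes the result in this assay: 3,4,5-trimethoxyphenyl in place of 2,3-dichlorophenyl gives a 5.6-fold lower number from compound 2 to compound 3 (0.75 log units; beyond the scatter). For the compounds shown here, this is the first measured step at this place, and it shows that the read-out responds to a change there. Nothing available accounts for the shift. The compounds shown leave open whether the chlorine atoms leaving or the methoxy groups entering carry the step. On these data alone, how an unsubstituted phenyl or a pyridine ring would read at this place also remains open.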